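This account rests on a few compounds, and the source may have more. Where it says the series, first, only, none or still open, it means among the compounds named here.

Three compounds in the series have readings in an ADME assay on HEp-2 cells (Homo sapiens) for cytotoxicity; on this read-out higher numbers stand for lower toxicity in this test and lower numbers for higher toxicity in this test. Compound 1 `Cc1ccc(NC(=O)C(C)NS(=O)(=O)c2cccc3cccnc23)c(C)c1` gives > 50000 nM, which is a limit of the assay and not a number. Compound 2 `O=C(Nc1ccc(Cl)cc1Cl)[C@@H]1CCCN1S(=O)(=O)c1cccc2cccnc12` gives > 50000 nM, which is likewise a limit. The overall picture is the limit of > 50000 nM in this assay, at which 2 of the 3 values shown sit. For the measured compounds named here, compound 3 `Cc1ccc(C(F)(F)F)cc1NC(=O)[C@@H]1CCCN1S(=O)(=O)c1cccc2cccnc12` gives 4800 nM, the only actual number in the set, so there is no second numerical value to compare it with.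

Compound 4 `Cc1ccc(C(C)(C)C)cc1NC(=O)[C@@H]1CCCN1S(=O)(=O)c1cccc2cccnc12` keeps the core of compound 3 and alters one group: tert-butyl in place of trifluoromethyl on an aromatic carbon. The change is tert-butyl in place of trifluoromethyl on an aromatic carbon, meta to a large group and para to a methyl group. Going by the values given here, no measured pair isolates this change, and none of the compounds read so far carries tert-butyl. The expectation therefore rests on compound 3 at 4800 nM as the sole anchor.

With no evidence for a direction, no change beyond the usual scatter is expected, and the estimated step is a 1.0-fold higher number from compound 3 to compound 4 (0.02 log units; within the scatter). The uncertainty remains wide, and a reading that reaches only the assay limit is possible. Compound 4 is estimated at 5000 nM, with an expected range of 1800 nM to 20000 nM.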

Compound 4, half-maximal cytotoxic concentration: 6500 nM
For compound 4 the middle estimate is 1.3-fold (0.11 log units) below the measured one; low and high end bracket the measured number.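

In this assay, this position now has a readable step: tert-butyl in place of trifluoromethyl on an aromatic carbon, meta to a large group and para to a methyl group, gives a 1.4-fold higher number from compound 3 to compound 4 (0.13 log units; within the scatter). The two groups have the same heavy-atom count, 4 each, and neither adds a hydrogen-bond donor, an acceptor, a ring or a net charge; the exchange of the 3 fluorine atoms for carbon therefore leaves the reading within the scatter in this single pair. Compound 3 and compound 4 also provide the only actual numbers in a set otherwise defined by the assay limit: the limit of > 50000 nM in this assay, at which 2 of the 4 values shown sit.

Still open, going by these compounds, is whether an amine, a carboxylic acid or a longer alkyl chain on this aromatic carbon would move the reading in this assay beyond the scatter. For the compounds shown here, compound 1 and compound 2 each differ from compound 3 and compound 4 in more than one place, so no step to either can be read, and what separates the numerical readings from the limit readings stays unresolved.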